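The compounds below may be only part of what the source reports. "The series", "measured", "known", "first", "only" and "open" are said of these compounds alone.

Measured so far:
compound 1, `CCCCc1c(Cl)cc(N/C=N/OCC)cc1Cl`: 5.6
compound 2, `CCO/N=C/Nc1cc(Cl)c(O)c(Cl)c1`: 2.8
compound 3, `C#CCOc1c(Cl)cc(N/C=N/OCC)cc1Cl`: 3.6

In a physicochemical assay for lipophilicity, measured as octanol-water partition (a higher number here means a more lipophilic compound, a lower number a more polar compound), compound 1 stands highest of the three, with compound 3 nearest and compound 2 furthest. The open step leads from compound 1 to compound 4, `CCO/N=C/Nc1cc(Cl)c(OCOC)c(Cl)c1`, the change being (methoxymethoxy in place of butyl on an aromatic carbon). For the measured compounds named here, two measured steps bear on it: a number 2.80 log units lower from compound 1 to compound 2 (beyond the scatter) and a number 2.00 log units lower from compound 1 to compound 3 (beyond the scatter), both large, both downward, both beyond the scatter. Going by the values given here, the change to compound 4 is of the same kind, an oxygen-linked group of four heavy atoms replacing butyl on the same aromatic carbon, so a large downward step in this assay is expected, closer to the one seen for compound 3 than for compound 2; the expected step is a number 2.30 log units lower from compound 1 to compound 4 (beyond the scatter). For compound 4 the estimate in this assay is 3.3, within a range from 2.8 to 3.8.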

Compound 4, partition coefficient: 3.7
Estimate against measurement, compound 4: 0.40 log units below; measured number inside the range.
By their numbers in this assay, from the lowest: compound 2; then compounds 3 and 4 (each within the scatter of the next); then compound 1.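

In this assay, methoxymethoxy in place of butyl on this aromatic carbon gives a number 1.90 log units lower from compound 1 to compound 4 (beyond the scatter), in the same direction as the two earlier replacements of butyl. Methoxymethyl in place of hydrogen on the oxygen gives a number 0.90 log units higher from compound 2 to compound 4 (beyond the scatter), and methoxy in place of ethynyl on the chain carbon gives a number 0.10 log units higher from compound 3 to compound 4 (within the scatter), so the chain ends of compound 3 and compound 4 are not told apart here. No measured evidence bears on the size of these steps.

Still open, from the compounds shown here alone, is how an amine, a carboxylic acid or a longer alkoxy chain on this aromatic carbon would compare in this assay. Also open, going by these compounds, is whether these steps hold with other groups in place of the two chloro groups.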